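The source may hold more compounds than are shown below. What is called first, only, known or untested is meant among the compounds shown, and "the series" means these compounds.

Measured in an ADME assay on MT4 cells (Homo sapiens) for cytotoxicity, read by MTT assay; on this read-out higher numbers stand for lower toxicity in this test and lower numbers for higher toxicity in this test:
- Compound 1 `Cc1cc(C)cc(S(=O)(=O)c2c(C(=O)NCc3cccc(N)c3)[nH]c3ccc(Cl)cc23)c1`: > 53400 nM (a limit)
- Compound 2 `Cc1cc(C)cc(S(=O)(=O)c2c(C(=O)Nc3ccnc(C#N)c3)[nH]c3ccc(Cl)cc23)c1`: 6840 nM
- Compound 3 `Cc1cc(C)cc(S(=O)(=O)c2c(C(=O)NCc3n[nH]c4ccccc34)[nH]c3ccc(Cl)cc23)c1`: > 50700 nM (a limit)

The value of compound 3, > 50700 nM, is a limit and not a number. Compound 4 `Cc1cc(C)cc(S(=O)(=O)c2c(C(=O)NC(c3ccc(Cl)cc3)C3CC3)[nH]c3ccc(Cl)cc23)c1` keeps the shared core but changes the group on the amide-type nitrogen: a group of 11 heavy atoms (10 carbon, 1 chlorine; one three-membered non-aromatic ring of carbon only, one six-membered aromatic ring of carbon only) in place of a group of 10 heavy atoms (8 carbon, 2 nitrogen; one five-membered aromatic ring with 2 hetero atoms, one six-membered aromatic ring of carbon only), on an amide-type nitrogen.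

Swaps at this same nitrogen have moved the number before, with an at least 7.8-fold lower number from compound 1 to compound 2 (0.89 log units; beyond the scatter) and an at least 7.4-fold higher number from compound 2 to compound 3 (0.86 log units; beyond the scatter), while a step that the two limits leave unreadable from compound 1 to compound 3. Among the compounds with values here, the group entering compound 4 appears in no measured compound, so the limit need not carry over, and a moderately lower number is expected. In this assay the expected step is an at least 2.5-fold lower number from compound 3 to compound 4 (0.40 log units; beyond the scatter). For compound 4 the estimate is 20000 nM, with an expected range of 6000 nM to 60000 nM.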

Compound 4, half-maximal cytotoxic concentration: > 47300 nM
Compound 4: only a limit was reported; the forecaster's own chance of this, stated with the estimate: 40%; at least 2.3-fold (0.37 log units) between middle value and limit.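

In this assay compound 4 gives > 47300 nM, which is a limit and not a number. The group with 0 hydrogen-bond donors and 0 hydrogen-bond acceptors on the amide-type nitrogen therefore also reaches a limit, as the (1H-indazol-3-yl)methyl group with 1 of each did, and only the 2-cyanopyridin-4-yl group stands apart: an at least 6.9-fold higher number from compound 2 to compound 4 (0.83 log units; beyond the scatter). The steps from compound 1 and compound 3 to compound 4 cannot be read.

Going by these compounds, how far these three compounds differ remains open, as does whether a carboxylic acid at this nitrogen would give a measurable number.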